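This account rests on a few compounds, and the source may have more. Where it says the series, first, only, none or still open, it means among the compounds named here.

Measured so far:
Compound 1 `CCOC(=O)c1cc2c(-c3cccnc3)nn(-c3ccccc3)c2nc1-c1cccnc1`: 6.9 ug/mL
Compound 2 `N#Cc1cc2c(-c3cccnc3)nn(-c3ccccc3)c2[nH]c1=O`: 3 ug/mL

In a functional assay on MCF7 cells (Homo sapiens) for cytotoxicity, read by sulforhodamine B assay (on this read-out higher numbers stand for weaker inhibition and lower numbers for stronger inhibition), compound 2 has the lowest of these two numbers; the number for compound 1 is higher, and the gap lies beyond the usual scatter. Among the compounds with values here, no single-point step between them is available. Compound 3 `O=C(c1ccc(F)cc1)c1cc2c(-c3cccnc3)nn(-c3ccccc3)c2[nH]c1=O` differs from compound 2 by (4-fluorophenyl)carbonyl in place of cyano on an aromatic carbon. Within the data shown here, no measured pair shows this kind of change, so its direction cannot be read from the two measured compounds. The expected step is therefore small: a 1.3-fold higher number from compound 2 to compound 3 (0.12 log units; within the scatter), not clearly beyond the scatter. Compound 3 is estimated at 4 ug/mL, within a range of 1.5 ug/mL to 12 ug/mL.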

Compound 3, half-maximal inhibitory concentration: 8.7 ug/mL
Beside the measured number, compound 3's estimate is 2.2-fold (0.34 log units) below it; the measured number falls inside the stated range.
By their numbers in this assay, from the lowest: compound 2; then compounds 1 and 3 (each within the scatter of the next).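

At this aromatic carbon, replacing cyano with the larger (4-fluorophenyl)carbonyl in this assay gives a 2.9-fold higher number from compound 2 to compound 3 (0.46 log units; beyond the scatter) and so weakens inhibition modestly, without abolishing it. Within the data shown here, this is the first single-place comparison, and it shows that the position accepts an added aromatic ring at that modest cost. No measured evidence explains this step. As far as these compounds go, whether an amine or a carboxylic acid at this carbon would give stronger or weaker inhibition remains open. So does whether the fluorine or the carbonyl matters more within the new group.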